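Dropping the Dimethylamino Group: Expected Cytotoxicity Shift

A few compounds are considered here, and "the series" means these few. Any claim that something is new, unique, unknown or untested is made for them only; others in the source may bear on it.

Compound 1 `Cc1c(C(=O)N/N=C/c2ccco2)no[n+]1[O-]`: in an ADME assay on J774.1 cells (Mus musculus) for cytotoxicity, read by MTT assay, with a stated time of 48 h (on this read-out higher numbers stand for weaker inhibition and lower numbers for stronger inhibition), compound 1 gives > 400000 nM, which is a limit of the assay and not a number.
Compound 2 `COc1cc(/C=N/NC(=O)c2no[n+]([O-])c2C)ccc1O`: in this assay compound 2 gives > 400000 nM, again a limit and not a number.
Compound 3 `Cc1c(C(=O)N/N=C/c2ccc(N(C)C)cc2)no[n+]1[O-]`: in this assay compound 3 gives 129000 nM.

Among the measured compounds shown here, of the three measured compounds, compound 3 is the only one with an actual number; the other two sit at the limit of > 400000 nM in this assay, at which 2 of the 3 values shown sit. For the measured compounds named here, compound 3 therefore stands as the single fixed point, with no measured step to any neighbour from which the size of a change could be read.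

Compound 4 `Cc1c(C(=O)N/N=C/c2ccccc2)no[n+]1[O-]` differs from compound 3 in one place: hydrogen in place of dimethylamino on an aromatic carbon. Two of the three compounds already measured stop at the limit, so a compound that loses the dimethylamino group seems more likely to drift toward that limit than away from it. The expected step in this assay is a loss of potency of moderate size, beyond the usual scatter but not far beyond it, with a real chance that only a limit is reported.

For compound 4 the estimated value in this assay is 300000 nM, with a range from 100000 nM to 900000 nM, which corresponds to an expected step of a 2.3-fold higher number from compound 3 to compound 4 (0.37 log units; beyond the scatter).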

Compound 4, half-maximal inhibitory concentration: > 400000 nM
Compound 4: a limit, no number; the forecaster's own chance of this, stated with the estimate: 50%; at least 1.3-fold (0.12 log units) between middle value and limit.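

Among the compounds shown here, at this place on the six-membered aromatic ring, para to a large group, hydrogen in place of dimethylamino gives, in this assay, an at least 3.1-fold higher number from compound 3 to compound 4 (0.49 log units; beyond the scatter), which is the first step in this set that can be read at all and which lies beyond the scatter. From the compounds shown here alone, compound 4 gives > 400000 nM, a limit of the assay and not a number, so the step has only a lower bound and its full size remains unknown. Compound 3 is now the one compound here with an actual number, and the step between compound 1 and compound 4 cannot be read, as both values are limits: the limit of > 400000 nM in this assay, at which 3 of the 4 values shown sit.

Going by these compounds, what stays open is whether the lower number of compound 3 belongs to dimethylamino in particular or would also come with a plain amine or a carboxylic acid at the same place. Also open, on these data alone, are how large the step really is and whether the same change would give a similar step on a different core.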